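Pyridin-3-yl for 4-fluorophenyl: stability notes

The source may report more compounds than this note shows. Statements on the series, on what has been measured and on what is new or still open speak of the compounds shown alone.

In an ADME assay on microsomes from liver (Homo sapiens) for metabolic stability, with a stated time of 10 min, tested at 0.5 uM (on this read-out lower numbers stand for a less stable compound and higher numbers for a more stable compound), compound 2 `Cc1onc(-c2ccc(F)cc2)c1[C@@H]1C[C@@](C)(c2ccc(F)cc2F)N=C(N)S1` gives 24% and stands within the scatter of compound 1 `CCc1noc(C)c1[C@@H]1C[C@@](C)(c2ccc(F)cc2F)N=C(N)S1` at 21% in this series. The change to compound 3 `Cc1onc(-c2cccnc2)c1[C@@H]1C[C@@](C)(c2ccc(F)cc2F)N=C(N)S1` is pyridin-3-yl in place of 4-fluorophenyl on an aromatic carbon at the same aromatic carbon. For the measured compounds named here, the one measured step at this place is a number 3 percentage points higher from compound 1 to compound 2 (within the scatter) and stays small, though it involves no pyridin-3-yl. No shift beyond the scatter is therefore expected. The estimated move is a number 5 percentage points higher from compound 2 to compound 3 (within the scatter) and no more. Compound 3 is expected at 29% with an estimated range of 16% to 46% in this assay when measured.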

Compound 3, percent of the compound remaining: 17%
The estimate for compound 3 lay 12 percentage points above the measured number; the range from low to high includes it.
By their numbers in this assay, from the lowest: compounds 3, 1 and 2 (each within the scatter of the next).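

At this aromatic carbon, this assay shows a number 7 percentage points lower from compound 2 to compound 3 (within the scatter) and, against the smaller group, a number 4 percentage points lower from compound 1 to compound 3 (within the scatter). Ethyl, 4-fluorophenyl and pyridin-3-yl thus all lie within the scatter of one another, and going from a ring of carbon only to one with a hetero atom gives no shift beyond it. Nothing on hand explains why these numbers stay so close. From the compounds shown here alone, whether an amine or a carboxylic acid at this carbon would move the number beyond the scatter stays open. So does the reading for a pyridin-3-yl isomer such as pyridin-4-yl.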